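Phenyl in Place of Methoxyphenoxy: Expected Solubility of Compound 4

A few compounds are considered here, and "the series" means these few. Any claim that something is new, unique, unknown or untested is made for them only; others in the source may bear on it.

Compound 3 `COc1ccc(Oc2ccc3c(NCCCNCc4cccc(OC)c4O)ccnc3c2)cc1` gives 14500 nM in a physicochemical assay for solubility, with a stated time of 18 h, at pH 7.4; on this read-out lower numbers stand for lower solubility and higher numbers for higher solubility. It stands level with compound 2 `COc1cccc(Oc2ccc3c(NCCCNCc4cccc(OC)c4O)ccnc3c2)c1`, which in this assay gives 14500 nM, and the two share the lowest number among the three measured compounds. Compound 1 `COc1cccc(CNCCCNc2ccnc3cc(-c4ccc(F)cc4)ccc23)c1O` gives 32000 nM in this assay, the highest of the three. The measured steps are a 2.2-fold lower number from compound 1 to compound 2 (0.34 log units; beyond the scatter), a 2.2-fold lower number from compound 1 to compound 3 (0.34 log units; beyond the scatter), and no change at the digits printed from compound 2 to compound 3 (within the scatter).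

Compound 4 `COc1cccc(CNCCCNc2ccnc3cc(-c4ccccc4)ccc23)c1O` differs from compound 3 by phenyl in place of 4-methoxyphenoxy on an aromatic carbon. Going by the values given here, the steps that bear on this change are the two from compound 1, in which a 4-fluorophenyl gave way to a 3-methoxyphenoxy or a 4-methoxyphenoxy and the number fell by a modest amount beyond the scatter. The change to compound 4 runs the other way: the methoxyphenoxy leaves and a phenyl enters, a group closer to the 4-fluorophenyl of compound 1 than to the groups of compounds 2 and 3. A modest rise back toward the number of compound 1 is therefore expected, namely a 2.1-fold higher number from compound 3 to compound 4 (0.32 log units; beyond the scatter). Compound 4 is estimated at 30000 nM, with an expected range from 12000 nM to 70000 nM.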

Compound 4, solubility: 32000 nM
Compound 4: the middle estimate sits 1.1-fold (0.03 log units) below what was measured, and the stated range covers the measured number.
By their numbers in this assay, from the lowest: compounds 2 and 3 (each within the scatter of the next); then compounds 1 and 4 (each within the scatter of the next).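

In this assay, phenyl in place of 4-methoxyphenoxy gives a 2.2-fold higher number from compound 3 to compound 4 (0.34 log units; beyond the scatter), and phenyl in place of 3-methoxyphenoxy gives a 2.2-fold higher number from compound 2 to compound 4 (0.34 log units; beyond the scatter), so the two methoxyphenoxy compounds now stand apart from an unsubstituted phenyl as well as from the 4-fluorophenyl of compound 1. Going by these compounds alone, the step from the 4-fluorophenyl to the phenyl, hydrogen in place of fluoro, gives no change at the digits printed from compound 1 to compound 4 (within the scatter), which shows that the read-out does not separate these two aryl groups at this aromatic carbon, something the earlier compounds could not show because they held only one directly attached phenyl group. No measurement shown here accounts for the difference between the phenyl groups and the methoxyphenoxy groups.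

Going from phenyl to either methoxyphenoxy group adds both a linking oxygen and a methoxy, so the compounds shown do not tell which of the two goes with the lower number, and a plain phenoxy at this carbon would divide them. On these data alone, how a phenyl bearing an amine or a carboxylic acid would read in this assay also remains open.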